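The compounds below may be only part of what the source reports. "The series", "measured", "known", "first", "only" and "open" are said of these compounds alone.

Going by the values given here, in an ADME assay on the whole organism (strain CD-1) for pharmacokinetics, with Mus musculus as the target, at a dose of 3 mg/kg by the intravenous route (on this read-out lower numbers stand for lower exposure and higher numbers for higher exposure at the dose given), only two compounds have numbers so far. Compound 1 `CN(Cc1ccccc1OCCCCC(C)(C)C(=O)O)C(=O)c1ccc(-c2ccco2)cc1` gives 48400 ng.h/mL in this read-out, and compound 2 `C[C@@H](CCCOc1ccccc1CN(C)C(=O)c1ccc(-c2ccco2)cc1)CC(=O)O` gives 30800 ng.h/mL on the same scale. Among the compounds with values here, compound 2 therefore stands level with its only measured neighbour, within the scatter.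

Compound 3 `CN(Cc1ccccc1OCCC[C@@H]1C[C@H]1C(=O)O)C(=O)c1ccc(-c2ccco2)cc1` keeps the shared core and alters one group. It carries 2-carboxycyclopropyl in place of 1-(carboxymethyl)ethyl, on a saturated chain carbon, three bonds along the chain from an oxygen on an aromatic ring (2-carboxycyclopropyl in place of 1-(carboxymethyl)ethyl on a saturated chain carbon, three bonds along the chain from an oxygen on an aromatic ring).

Within the data shown here, only one measured step bears on this, and it changes the same place on the chain. That step is a 1.6-fold lower number from compound 1 to compound 2 (0.20 log units; within the scatter) and it does not go beyond the scatter. Among the measured compounds shown here, it is thin evidence, since no compound with a three-membered ring has been measured here. No shift beyond the scatter is therefore expected, in either direction, and the estimate amounts to a 1.0-fold lower number from compound 2 to compound 3 (0.01 log units; within the scatter) as the expected step. Compound 3 is estimated at 30000 ng.h/mL with 12000 ng.h/mL to 75000 ng.h/mL as the expected range, kept wide for that reason.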

Compound 3, area under the concentration-time curve: 40500 ng.h/mL
Compound 3: the middle estimate sits 1.4-fold (0.13 log units) below what was measured; the range from low to high includes it.
By their numbers in this assay, from the lowest: compounds 2, 3 and 1 (each within the scatter of the next).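

In this assay, tying the end of the chain into a three-membered carbon ring leaves the number where it was, with a 1.3-fold higher number from compound 2 to compound 3 (0.12 log units; within the scatter), and the comparison with the branched group gives a 1.2-fold lower number from compound 1 to compound 3 (0.08 log units; within the scatter). This place on the chain, three bonds along from the oxygen on the aromatic ring, has now carried 2-carboxy-2-methylpropyl, 1-(carboxymethyl)ethyl and 2-carboxycyclopropyl, and all three compounds lie within the scatter of one another, so a ring at this point is no departure from the open-chain groups on this read-out. Nothing available here accounts for how closely these numbers agree.

The compounds shown leave open how exposure would respond if the carboxylic acid gave way to a primary amide or an amine, or if the chain carrying it were longer. They also leave open whether the 2-carboxycyclopropyl group, with its two defined stereocentres, would read the same with those centres arranged the other way.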